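The source may report more compounds than this note shows. Statements on the series, on what has been measured and on what is new or still open speak of the compounds shown alone.

Measured compounds:
compound 1, `O=C(Nc1cc(C(F)(F)F)ccc1N1CCCCC1)c1cccnc1Cl`, "not active" (no number reported) in a functional assay on HL-60 cells (Homo sapiens) for cytotoxicity, read by MTT assay, with a stated time of 48 h; on this read-out lower numbers stand for stronger inhibition and higher numbers for weaker inhibition
compound 2, `CCN(CC)c1ccc(C(F)(F)F)cc1NC(=O)c1ccncc1`, 89700 nM in this assay

Among the compounds with values here, compound 2 holds the only number found in this assay; compound 1 carries no number, being reported there as "not active" (no number reported). In this assay compound 2 gives 89700 nM, a weak result on its own, with nothing to order it against.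

Compound 3, `CCN(CC)c1ccc(C(F)(F)F)cc1NC(=O)c1cccnc1Cl`, has not yet been measured. It differs from compound 2 by 2-chloropyridin-3-yl in place of pyridin-4-yl on a carbonyl carbon. Within the data shown here, no step between measured compounds covers this change, so its size cannot be read from the data. Among the measured compounds shown here, the only pointer is compound 1, which carries the same 2-chloropyridin-3-yl amide on another core and is reported as "not active" (no number reported), so a drift toward weaker inhibition, or a report of no activity, is expected for compound 3 rather than a gain. The estimate for compound 3 in this assay is 150000 nM, within 40000 nM to 500000 nM, which means an expected step of a 1.7-fold higher number from compound 2 to compound 3 (0.22 log units; within the scatter).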

Compound 3, half-maximal inhibitory concentration: 84100 nM
Estimate against measurement, compound 3: 1.8-fold (0.25 log units) above; the range from low to high includes it.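

In this assay, putting 2-chloropyridin-3-yl in place of pyridin-4-yl on the carbonyl carbon gives a 1.1-fold lower number from compound 2 to compound 3 (0.03 log units; within the scatter), so this position tolerates the exchange without a readable change in the result. The 2-chloropyridin-3-yl amide therefore does not by itself go with the "not active" report for compound 1, since compound 3 carries the same amide on the shared diethylamine-bearing core and gives 84100 nM in this assay. No measurement is available to explain why the exchange leaves the number where it is.

The exchange adds the chlorine and moves the ring attachment in one step, and the compounds shown do not separate the two, as a plain pyridin-3-yl would. As far as these compounds go, whether any other group here, such as a phenyl ring or a pyridine bearing an amine or a carboxylic acid, would give a markedly lower number also remains open.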